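Compound 3 to compound 4: one chloro leaves

The compounds below may be only part of what the source reports. "The series", "measured", "known", "first", "only" and "open" are said of these compounds alone.

In a functional assay on HCT-116 cells (Homo sapiens) for antiproliferative activity, read by MTT assay, with a stated time of 72 h (a lower number here means a stronger inhibitor, a higher number a weaker inhibitor), compound 3 `NC1=NC2(CCOCC2)N(OCCCOc2ccc(Cl)c(Cl)c2)C(N)=N1` gives the lowest of three numbers at 90 nM, ahead of compound 2 `NC1=NC2(CCOCC2)N(OCCCOc2ccc(Cl)cc2)C(N)=N1` at 690 nM and compound 1 `COc1ccc(OCCCON2C(N)=NC(N)=NC23CCOCC3)cc1` at 1500 nM. Compound 4 `NC1=NC2(CCOCC2)N(OCCCOc2cccc(Cl)c2)C(N)=N1` has hydrogen in place of chloro on an aromatic carbon, 3,4-dichlorophenyl becoming 3-chlorophenyl: hydrogen in place of chloro on an aromatic carbon. The closest guide runs the opposite way, with a chloro entering in a 7.7-fold lower number from compound 2 to compound 3 (0.88 log units; beyond the scatter). The smaller 2.2-fold lower number from compound 1 to compound 2 (0.34 log units; beyond the scatter) also favours chloro on the aromatic ring. Compound 4 keeps a different chloro from compound 2, so the mirror is only rough. A modest rise is expected, estimated as a 3.3-fold higher number from compound 3 to compound 4 (0.52 log units; beyond the scatter). The estimate for compound 4 is 300 nM, with an expected range of 120 nM to 800 nM.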

Compound 4, half-maximal inhibitory concentration: 120 nM
The estimate for compound 4 lay 2.5-fold (0.40 log units) above the measured number; low and high end bracket the measured number.
By their numbers in this assay, from the lowest: compounds 3 and 4 (each within the scatter of the next); then compound 2; then compound 1.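

In this assay the chloro para to a large group can leave with only a 1.3-fold higher number from compound 3 to compound 4 (0.12 log units; within the scatter) as the result, so 3-chlorophenyl alone matches 3,4-dichlorophenyl within the scatter. The place of a single chloro matters: 3-chlorophenyl in place of 4-chlorophenyl gives a 5.8-fold lower number from compound 2 to compound 4 (0.76 log units; beyond the scatter) and 3-chlorophenyl in place of 4-methoxyphenyl gives a 13-fold lower number from compound 1 to compound 4 (1.10 log units; beyond the scatter) in this series. No measurement at hand offers a reason for this dependence on place.

Open, from the compounds shown here alone, is whether a nitrile, a methyl or an amine on the carbon now holding the remaining chloro would keep this level. Going by these compounds, the effect of a longer chain with 3-chlorophenyl also remains open.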